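This account rests on a few compounds, and the source may have more. Where it says the series, first, only, none or still open, it means among the compounds named here.

Measured compounds:
Compound 1 `Cc1cc(C)c(S(=O)(=O)N2CCC(N3CCC(C)CC3)CC2)c(C)c1`: > 5000 nM
Compound 2 `CC1CCN(C2CCN(S(=O)(=O)c3cn(C)c(=O)n(C)c3=O)CC2)CC1`: > 10000 nM
Compound 3 `Cc1noc(C)c1S(=O)(=O)N1CCC(N2CCC(C)CC2)CC1`: > 10000 nM

In an ADME assay on HCT-116 cells (Homo sapiens) for cytotoxicity, read by CellTiter-Glo, with a stated time of 72 h (a lower number here means a stronger inhibitor, a higher number a weaker inhibitor), compound 1 gives > 5000 nM, which is a limit of the assay and not a number. The results for compound 2 and compound 3 are limits too, so none of the three compounds has an actual number and they cannot be ranked.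

Compound 4 `Cc1cc(C)c(S(=O)(=O)N2CCC(N3CCC(c4ccccc4)CC3)CC2)c(C)c1` keeps the core of compound 1 but carries phenyl in place of methyl on a saturated ring carbon. For the measured compounds named here, no two measured compounds differ in one place alone, so no measured step can serve as a guide to this change. The expectation in this assay is therefore cautious: a small move toward a lower number, perhaps none beyond the usual scatter. The expected step of an at least 1.2-fold lower number from compound 1 to compound 4 (0.09 log units; that floor lies within the scatter) is only a rough estimate. For compound 4 the estimated value is 4000 nM, with an expected range from 1500 nM to 12000 nM.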

Compound 4, half-maximal inhibitory concentration: > 5000 nM
Compound 4 was reported as a limit; the forecaster's own chance of this, stated with the estimate: 55%; at least 1.2-fold (0.09 log units) between middle value and limit.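

Compound 1 and compound 4 are both reported only as limits in this assay, and no step can be read between them. The compounds shown leave open what actual number either would give, and whether phenyl in place of methyl changes it at all.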